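Methyl to Bromo on the Ring Attached to the Carbonyl

The compounds below may be only part of what the source reports. "The series", "measured", "known", "first", "only" and "open" are said of these compounds alone.

Within the data shown here, compound 2 `Cc1ccc(C(=O)N2CCN(Cc3nc4ccccc4n3Cc3cccc(C)c3)CC2)cc1` holds the higher of the two numbers measured so far: in an assay on isolated protein for inhibition of aldehyde dehydrogenase 1A1 (Homo sapiens), read by spectrophotometry, tested at 10 uM (a lower number here means less inhibition, a higher number more inhibition at the concentration tested (going by the name of the read-out)), compound 2 gives 64.9%. Among the measured compounds shown here, its only neighbour, compound 1 `Cc1cccc(Cn2c(CN3CCN(C(=O)c4ccncc4)CC3)nc3ccccc32)c1`, gives 20.6% in this assay, and the single measured step, a number 44.3 percentage points higher from compound 1 to compound 2 (beyond the scatter), comes from placing 4-methylphenyl in place of pyridin-4-yl on the carbonyl carbon.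

Compound 3 `Cc1cccc(Cn2c(CN3CCN(C(=O)c4ccc(Br)cc4)CC3)nc3ccccc32)c1` differs from compound 2 by bromo in place of methyl on an aromatic carbon. For the measured compounds named here, no measured step exchanges one substituent for another on this ring; the one step recorded swaps the whole ring attached to the carbonyl, and so shows only that this part of the molecule matters to the read-out. Exchanging one atom for another at one place is expected to move the number far less, by about a number 4.9 percentage points lower from compound 2 to compound 3 (within the scatter). Compound 3 is therefore estimated at 60%, within a range from 40% to 80%.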

Compound 3, a percentage reported as inhibition, at one concentration (the size of the read-out at that concentration, not a potency): 25.8%
For compound 3 the middle estimate is 34.2 percentage points above the measured one; the whole stated range lies above it.
By their numbers in this assay, from the lowest: compounds 1 and 3 (each within the scatter of the next); then compound 2.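

Among these compounds, the ring attached to the carbonyl is not the only thing that matters here: the single group on it, para to a large group, can decide the result in this assay. Bromo in place of methyl gives a number 39.1 percentage points lower from compound 2 to compound 3 (beyond the scatter), a large change from exchanging one heavy atom for another. Compound 3 keeps a six-membered aromatic ring of carbon only, yet a number 5.2 percentage points higher from compound 1 to compound 3 (within the scatter) shows that 4-bromophenyl in place of pyridin-4-yl leaves the number within the scatter, so the higher number of compound 2 does not come with every such ring. Nothing available explains why this one exchange has so large an effect. The compounds shown leave open whether chloro, methoxy or a longer chain such as ethyl in the same place would behave like the methyl of compound 2 or the bromo of compound 3. They also leave open whether the methyl would give a similar number elsewhere on this ring.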